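The source may hold more compounds than are shown below. What is called first, only, known or untested is meant among the compounds shown, and "the series" means these compounds.

Compound 1 `NS(=O)(=O)NCC1CCN(c2cc(-c3ccc(Cl)cc3)ncn2)CC1`: 25500 nM
Compound 2 `NS(=O)(=O)NCC1CCN(c2cc(-c3cccc(Cl)c3)ncn2)CC1`: 47100 nM
Compound 3 `NS(=O)(=O)NCCC1CCN(c2cc(-c3ccc(Cl)cc3)ncn2)CC1`: 19700 nM

All three were tested in a functional assay on MCF7 cells (Homo sapiens) for antiproliferative activity, read by sulforhodamine B assay, with a stated time of 48 h; a higher number here means a weaker inhibitor of growth, a lower number a stronger inhibitor of growth. Compound 2 differs from compound 1 by 3-chlorophenyl in place of 4-chlorophenyl on an aromatic carbon, and this change gave a 1.8-fold higher number from compound 1 to compound 2 (0.27 log units; within the scatter). The core of compound 3 differs from that of compound 1 by (sulfamoylamino)methyl in place of sulfamoylamino on a saturated chain carbon bound to a saturated ring carbon, a change that gave a 1.3-fold lower number from compound 1 to compound 3 (0.11 log units; within the scatter). Compound 4 `NS(=O)(=O)NCCC1CCN(c2cc(-c3cccc(Cl)c3)ncn2)CC1` has not yet been measured; it differs from compound 3 by 3-chlorophenyl in place of 4-chlorophenyl on an aromatic carbon, which is the same change as that made between compound 1 and compound 2, at the same place. Within the data shown here, because the only earlier reading of this change was a 1.8-fold higher number from compound 1 to compound 2 (0.27 log units; within the scatter), compound 4 is expected to show a 1.8-fold higher number from compound 3 to compound 4 (0.25 log units; within the scatter), an expectation resting on that single pair alone. Compound 4 is therefore estimated at 35000 nM, with a likely range from 18000 nM to 70000 nM.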

Compound 4, concentration for 50% growth inhibition: 31200 nM
Estimate against measurement, compound 4: 1.1-fold (0.05 log units) above; the range from low to high includes it.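

In this assay, 3-chlorophenyl in place of 4-chlorophenyl gave a 1.6-fold higher number from compound 3 to compound 4 (0.20 log units; within the scatter), which agrees with the earlier reading of this change on another core: the same change on two cores in this assay, a 1.8-fold higher number (0.27 log units; within the scatter) from compound 1 to compound 2 and a 1.6-fold higher number (0.20 log units; within the scatter) from compound 3 to compound 4, 1.2-fold (0.07 log units) apart, within the scatter of two such steps. The longer chain gave a 1.5-fold lower number from compound 2 to compound 4 (0.18 log units; within the scatter), which also agrees with its earlier reading: the same change on two cores in this assay, a 1.3-fold lower number (0.11 log units; within the scatter) from compound 1 to compound 3 and a 1.5-fold lower number (0.18 log units; within the scatter) from compound 2 to compound 4, 1.2-fold (0.07 log units) apart, within the scatter of two such steps. Both changes thus carried from one core to the other without a gap beyond the scatter, but each step is itself within the scatter, so this shows neither a real effect of either change nor a rule for the wider series.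

On these data alone, it remains open whether a longer chain carrying the sulfamoylamino group would shift growth inhibition beyond the scatter. The same question applies to an unsubstituted phenyl or a methoxyphenyl in place of the chlorophenyl.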